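This account rests on a few compounds, and the source may have more. Where it says the series, first, only, none or still open, it means among the compounds named here.

Working notes on the series. Compound 1 `NC(=S)c1ccc(OC(=O)c2cccnc2)cc1` and compound 2 `O=C(Oc1ccc(-c2cc(=S)ss2)cc1)c1cccnc1` share one core; compound 3 `CC(C)(Oc1ccc(Cl)cc1)C(=O)Oc1ccc(C(N)=S)cc1` and compound 4 `CC(C)(Oc1ccc(Cl)cc1)C(=O)Oc1ccc(-c2cc(=S)ss2)cc1` share another, and the difference between the two cores is not broken down here. Among the measured compounds shown here, in an ADME assay on HUVEC cells (Homo sapiens) for cytotoxicity, read by MTT assay, with a stated time of 48 h (a lower number here means a stronger inhibitor, a higher number a weaker inhibitor), compound 1 gives 683000 nM, compound 2 gives 562000 nM and compound 3 gives 755000 nM; the values of compound 3 and the other two lie within the usual scatter of one another, and no step between them is counted.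

The change from compound 1 to compound 2 is a group of 6 heavy atoms (3 carbon, 3 sulfur; one five-membered aromatic ring with 2 hetero atoms) in place of a group of 3 heavy atoms (1 carbon, 1 nitrogen, 1 sulfur; no ring), on an aromatic carbon, and it made a 1.2-fold lower number from compound 1 to compound 2 (0.08 log units; within the scatter). The change from compound 3 to compound 4 is a group of 6 heavy atoms (3 carbon, 3 sulfur; one five-membered aromatic ring with 2 hetero atoms) in place of a group of 3 heavy atoms (1 carbon, 1 nitrogen, 1 sulfur; no ring), on an aromatic carbon, the same kind of change rather than the same, since the group that the place sits para to differs between compound 1 and compound 3. With one measured instance of this change, the expectation for compound 4 rests on a 1.2-fold lower number from compound 1 to compound 2 (0.08 log units; within the scatter), so in this assay the step is expected, for compound 4, at a 1.2-fold lower number from compound 3 to compound 4 (0.07 log units; within the scatter). Compound 4 is accordingly estimated at 650000 nM, expected to fall between 350000 nM and 1200000 nM.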

Compound 4, half-maximal inhibitory concentration: 617000 nM
Beside the measured number, compound 4's estimate is 1.1-fold (0.02 log units) above it; the range from low to high includes it.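

In this assay, the five-membered aromatic ring group in place of the open group of 3 heavy atoms gives a 1.2-fold lower number from compound 3 to compound 4 (0.09 log units; within the scatter), and the step reads the same on both cores: the same change on two cores in this assay, a 1.2-fold lower number (0.08 log units; within the scatter) from compound 1 to compound 2 and a 1.2-fold lower number (0.09 log units; within the scatter) from compound 3 to compound 4, 1.0-fold (0.00 log units) apart, within the scatter of two such steps. Within this series, the change therefore carries from the core of compound 1 to the core of compound 3 with no step beyond the scatter on either. This does not show a transferred effect of any measurable size, since the agreement is between two steps that are both within the scatter, and two pairs in one assay say nothing about cores outside these compounds.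

The compounds shown leave open how other groups at that aromatic carbon would read, such as an amine, a carboxylic acid or a nitrile. Also open, going by these compounds, is whether the change would stay this small on a core in which an amide takes the place of the ester link, or in a measure other than this cytotoxicity read-out.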